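The source may report more compounds than this note shows. Statements on the series, on what has been measured and on what is new or still open speak of the compounds shown alone.

Compound 1 `CCN(CC)CCCCOc1ccc(/C=C/C(=O)Nc2ccccc2)cc1OC` gives 1.59 in a physicochemical assay for lipophilicity, using the shake flask method, measured as octanol-water partition, at pH 7.4; a lower number here means a more polar compound, a higher number a more lipophilic compound; compound 2 `COc1cc(/C=C/C(=O)Nc2ccccc2)ccc1OCCCCCN(C)C` gives 1.61; compound 3 `COc1cc(/C=C/C(=O)Nc2ccccc2)ccc1OCCCCCN1CCCCC1` gives 1.65.

Compound 1 stands lowest of the three numbers, though compound 2 lies nearest at a number 0.02 log units higher from compound 1 to compound 2 (within the scatter) and compound 3 furthest at a number 0.06 log units higher from compound 1 to compound 3 (within the scatter), both within the scatter. Compound 4 `COc1cc(/C=C/C(=O)Nc2ccccc2)ccc1OCCCCCCCCCCN1CCCCC1` differs from compound 1 by 6-(piperidin-1-yl)hexyl in place of diethylamino on a saturated chain carbon, four bonds along the chain from an oxygen on an aromatic ring. Within the data shown here, of the measured steps, only a number 0.06 log units higher from compound 1 to compound 3 (within the scatter) and a number 0.04 log units higher from compound 2 to compound 3 (within the scatter) touch the amine end, and both were within the scatter; no measured step bears on the longer chain, so the bulk of the change is untested. The account therefore expects an upward step in this assay beyond the scatter, with a wide range. For compound 4 the estimate is 3.6, between 2.6 and 4.6, an expected step of a number 2.01 log units higher from compound 1 to compound 4 (beyond the scatter).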

Compound 4, partition coefficient: 1.83
The estimate for compound 4 lay 1.77 log units above the measured number, outside the stated range (below it).
By their numbers in this assay, from the lowest: compounds 1, 2, 3 and 4 (each within the scatter of the next).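

In this assay, 6-(piperidin-1-yl)hexyl in place of diethylamino, on a saturated chain carbon, four bonds along the chain from an oxygen on an aromatic ring, gives a number 0.24 log units higher from compound 1 to compound 4 (within the scatter), so a group of 12 heavy atoms in place of one of 5 still leaves the number inside the scatter. The other two routes to the same compound read a number 0.18 log units higher from compound 3 to compound 4 (within the scatter) and a number 0.22 log units higher from compound 2 to compound 4 (within the scatter), and neither separates the compounds either. Nothing measured here gives a reason for this. Still open, from the compounds shown here alone, is whether a carboxylic acid or a morpholine at the chain end would carry the number beyond the scatter. Going by these compounds, a shorter chain at this place remains equally open.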